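Methyl branching on ester-type and amide-type chains of a shared core

A few compounds are considered here, and "the series" means these few. Any claim that something is new, unique, unknown or untested is made for them only; others in the source may bear on it.

Compound 1 `CCNC(=O)C1=C(C)NC(=O)NC1c1ccco1` carries an ethylcarbamoyl group on its core. In an assay on membranes from HeLa cells for displacement of a labelled ligand from adenosine receptor A3 (Homo sapiens), read by scintillation counting, with a stated time of 180 min, tested at 1 uM (on this read-out lower numbers stand for less inhibition and higher numbers for more inhibition at the one concentration tested (going by the name of the read-out)), compound 1 gives 3%. Compound 2 `CC1=C(C(=O)NC(C)C)C(c2ccco2)NC(=O)N1` differs from it by methyl in place of hydrogen on a saturated chain carbon bound to an amide-type nitrogen and a saturated chain carbon, and in this assay compound 2 gives 4%. The step is a number 1 percentage points higher from compound 1 to compound 2 (within the scatter), so nothing separates the two within the usual scatter.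

Compound 3 `CCSC(=O)C1=C(C)NC(=O)NC1c1ccoc1` carries an (ethylsulfanyl)carbonyl group instead, and the difference between its core and the core of compound 1 is not broken down here. In this assay compound 3 gives 1%, within the scatter of compound 1 and compound 2.

Compound 4 `CC1=C(C(=O)SC(C)C)C(c2ccoc2)NC(=O)N1` has not yet been measured. It differs from compound 3 by methyl in place of hydrogen on a saturated chain carbon bound to a saturated chain carbon and a sulfur. This is the same kind of change as from compound 1 to compound 2, but the surroundings differ: there the carbon is bound to an amide-type nitrogen and a saturated chain carbon, here to a saturated chain carbon and a sulfur. Because the step of a number 1 percentage points higher from compound 1 to compound 2 (within the scatter) stayed within the scatter, compound 4 is expected to show a step of a number 2 percentage points higher from compound 3 to compound 4 (within the scatter). The estimate for compound 4 in this assay is 3%, between 0% and 12%.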

Compound 4, a percentage reported as inhibition, at one concentration (the size of the read-out at that concentration, not a potency): 3%
Beside the measured number, compound 4's estimate shows no gap at the digits printed; low and high end bracket the measured number.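

In this assay, methyl in place of hydrogen on a saturated chain carbon bound to a saturated chain carbon and a sulfur gives a number 2 percentage points higher from compound 3 to compound 4 (within the scatter). Set beside the earlier step, the same change reads alike on the two cores: the same change on two cores in this assay, a number 1 percentage points higher (within the scatter) from compound 1 to compound 2 and a number 2 percentage points higher (within the scatter) from compound 3 to compound 4, 1 percentage points apart, within the scatter of two such steps. This shows that, in these two pairs, the change carries from one core to the other without a step that stands out from the scatter, but neither step can be told from no change, so it does not show a shared effect of the methyl, nor how the change would carry over on a core with a larger read-out.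

The compounds shown leave open whether a longer chain such as propyl or butyl, a tert-butyl group, or a chain ending in an amine or a carboxylic acid would give a step beyond the scatter. Also open, from the compounds shown here alone, is how the (ethylsulfanyl)carbonyl group compares with the ethylcarbamoyl group on one and the same core.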